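The source may hold more compounds than are shown below. What is called first, only, known or untested is meant among the compounds shown, and "the series" means these compounds.

Measured compounds in a functional assay on PC-3 cells (Homo sapiens) for antiproliferative activity, read by MTT assay, with a stated time of 48 h; a lower number here means a stronger inhibitor, a higher number a weaker inhibitor:
- compound 1, `c1ccc(-c2nnc(-c3cn4ccccc4n3)o2)cc1`: 22200 nM
- compound 2, `COc1ccc(-c2nnc(-c3cn4ccccc4n3)o2)cc1`: 13400 nM
- compound 3, `COc1ccc(-c2nnc(-c3cn4cccc(C)c4n3)o2)cc1OC`: 11500 nM

Among the measured compounds shown here, the one single-point step among the measured set is a 1.7-fold lower number from compound 1 to compound 2 (0.22 log units; within the scatter), which brings (methoxy in place of hydrogen on an aromatic carbon). The difference between the core of compound 3 and the core of compound 1 is not broken down here; the values of compound 3 and compound 2 lie within the scatter of each other, as do those of compound 3 and compound 1, so no ordering among the three is claimed.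

Compound 4, `COc1cc(-c2nnc(-c3cn4cccc(C)c4n3)o2)cc(OC)c1OC`, has not yet been measured. It differs from compound 3 by methoxy in place of hydrogen on an aromatic carbon. This is the same kind of change as from compound 1 to compound 2, but not the same: there the methoxy entered para to a large group, here it enters ortho to a methoxy group, meta to a large group and meta to a methoxy group.

The expected step is a 1.2-fold lower number from compound 3 to compound 4 (0.06 log units; within the scatter), resting on a 1.7-fold lower number from compound 1 to compound 2 (0.22 log units; within the scatter) from compound 1 to compound 2, which was within the scatter. For compound 4 in this assay the estimate is 10000 nM, with a range from 5000 nM to 22000 nM.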

Compound 4, half-maximal inhibitory concentration: 10900 nM
The estimate for compound 4 lay 1.1-fold (0.04 log units) below the measured number; the range from low to high includes it.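

In this assay, methoxy in place of hydrogen on an aromatic carbon gives a 1.1-fold lower number from compound 3 to compound 4 (0.02 log units; within the scatter), so this second instance of the change also stays within the scatter. Set side by side, the two instances show no readable difference: the same change on two cores in this assay, a 1.7-fold lower number (0.22 log units; within the scatter) from compound 1 to compound 2 and a 1.1-fold lower number (0.02 log units; within the scatter) from compound 3 to compound 4, 1.6-fold (0.20 log units) apart, within the scatter of two such steps. This is consistent with the change carrying from one core to the other, but neither step can be told from the scatter, so it does not show that methoxy has a real effect on either core, and the two entries also sit at different places on the ring, so core and place are not separated.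

Open, going by these compounds, is whether a group other than methoxy on the six-membered aromatic ring of carbon only, such as an amine, a carboxylic acid or a longer chain, would move the number beyond the scatter. Also open, on these data alone, is how the methoxy change behaves on any core other than the core of compound 1 and the core of compound 3.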